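This account rests on a few compounds, and the source may have more. Where it says the series, first, only, none or still open, it means among the compounds named here.

Measured compounds:
compound 1, `Nc1nc(O)c2ncn([C@H]3C[C@@H](O)[C@@H](O)C3)c2n1` — in a functional assay on ESM cells (Homo sapiens), read by microscopy (on this read-out lower numbers stand for higher toxicity in this test and higher numbers for lower toxicity in this test), compound 1 gives > 400 ug/mL, which is a limit of the assay and not a number.
compound 2, `Nc1ncnc2c1ncn2[C@H]1C[C@@H](O)[C@@H](O)C1` — in this assay compound 2 gives > 400 ug/mL, likewise a limit of the assay.

Compound 2 thus stands at the limit of this assay, where both values shown sit (the limit of > 400 ug/mL in this assay, at which 2 of the 2 values shown sit). Within the data shown here, no step joining two measured compounds is available, so no measured change in this assay can be set beside the one that leads to compound 3.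

Compound 3, `Nc1nc(N)c2ncn([C@H]3C[C@@H](O)[C@@H](O)C3)c2n1`, differs from compound 2 by amino in place of hydrogen on an aromatic carbon. The change is the entry of an amino group in place of a hydrogen on an aromatic carbon of the core shared by compound 2 and compound 3. With both measured compounds sitting at the limit, the step of a number no higher from compound 2 to compound 3 (the limit leaves the size open) is expected to stay within the scatter, in no particular direction. Compound 3 is therefore expected to give 400 ug/mL in this assay, with a range from 200 ug/mL to 800 ug/mL, most likely reported as a limit again.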

Compound 3, minimum cytotoxic concentration: > 400 ug/mL
Compound 3: no number, only a limit; the forecaster's own chance of this, stated with the estimate: 85%; the middle value sits exactly at the limit.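

In this assay compound 3 gives > 400 ug/mL, which is a limit of the assay and not a number. The steps joining compound 3 to compound 1 and compound 2 therefore cannot be read: the limit of > 400 ug/mL in this assay, at which 3 of the 3 values shown sit.

The compounds shown leave open whether hydrogen, hydroxy or amino on that aromatic carbon makes any difference in this assay.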